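Estimating lipophilicity after an amide aryl swap

The source may hold more compounds than are shown below. What is called first, only, known or untested is meant among the compounds shown, and "the series" means these compounds.

Compounds measured in a physicochemical assay for lipophilicity; a lower number here means a more polar compound, a higher number a more lipophilic compound:
compound 1 `CCOC[C@H](Oc1ncnc2c1cnn2-c1ncccc1Cl)C(=O)Nc1ccc(Cl)cn1`: 3
compound 2 `Cc1cnc(NC(=O)[C@H](COC(C)C)Oc2ncnc3c2cnn3-c2ccccc2Cl)cn1`: 2.1
compound 3 `COC[C@H](Oc1ncnc2c1cnn2-c1ncccc1Cl)C(=O)Nc1ccc(C)cn1`: 2.3

Compound 2 holds the lowest of the three numbers in this assay. Its nearest neighbour is compound 3, whose value lies within the scatter of that of compound 2, so no order between them can be claimed. Compound 1 sits furthest away, beyond the scatter, with the higher number. Compound 4 `CC(C)OC[C@H](Oc1ncnc2c1cnn2-c1ccccc1Cl)C(=O)Nc1ccccn1` has not yet been measured. It differs from compound 2 in one place pyridin-2-yl in place of 5-methylpyrazin-2-yl on an amide-type nitrogen: a 5-methylpyrazin-2-yl group with two hydrogen-bond acceptors leaves, and a pyridin-2-yl group with one hydrogen-bond acceptor enters. Going by the values given here, no measured pair isolates this change. Compound 4 is expected to read somewhat higher in this assay, a step of a number 0.50 log units higher from compound 2 to compound 4 (beyond the scatter) that may reach beyond the scatter. The estimate for compound 4 is 2.6, with a range from 2.2 to 3.1.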

Compound 4, distribution coefficient: 3.5
Beside the measured number, compound 4's estimate is 0.90 log units below it, outside the stated range (above it).
By their numbers in this assay, from the lowest: compounds 2 and 3 (each within the scatter of the next); then compound 1; then compound 4.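

Pyridin-2-yl in place of 5-methylpyrazin-2-yl on an amide-type nitrogen moves the reading in this assay by a number 1.40 log units higher from compound 2 to compound 4 (beyond the scatter). Going by these compounds alone, this is the first pair in the set that differs in one place, and it shows that a single change of this group can shift the number well beyond the scatter. Nothing measured here accounts for the size of this step.

As far as these compounds go, the pair changes the methyl group and a ring nitrogen together, so their separate shares remain open. From the compounds shown here alone, whether an unsubstituted pyrazin-2-yl group on the same nitrogen would read nearer compound 2 or compound 4 also remains unknown.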